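The source may report more compounds than this note shows. Statements on the series, on what has been measured and on what is new or still open speak of the compounds shown alone.

Of the compounds shown here, three built on one shared core have so far been measured in an assay on CHO cells for displacement of a labelled ligand from adenosine receptor A1 (Homo sapiens), read by scintillation counting, with a stated time of 1 h, tested at 1 uM; on this read-out higher numbers stand for more inhibition at the one concentration tested (going by the name of the read-out) and lower numbers for less inhibition. Compound 1 `CCCCC(=O)Nc1ncc(-c2cccc(Cl)c2)c(-c2ccccc2)n1` gives 52%, compound 2 `O=C(Nc1ncc(-c2cccc(Cl)c2)c(-c2ccccc2)n1)C1CCC1` gives 52%, and compound 3 `CN(C)CCNc1ncc(-c2cccc(Cl)c2)c(-c2ccccc2)n1` gives 52%. The three differ only in the group carried on a nitrogen on an aromatic ring. no change at the digits printed from compound 1 to compound 2 (within the scatter), no change at the digits printed from compound 1 to compound 3 (within the scatter) and no change at the digits printed from compound 2 to compound 3 (within the scatter). Compound 3 therefore stands level with compounds 1 and 2 at the digits shown, one point in a flat set.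

Compound 4 `Clc1cccc(-c2cnc(NCc3ccccc3)nc2-c2ccccc2)c1` has not yet been measured. Compared with compound 3, the difference is phenyl in place of (dimethylamino)methyl on a saturated chain carbon bound to a nitrogen on an aromatic ring. The measured steps that bear most on this change are those that altered the group on that same ring nitrogen, no change at the digits printed from compound 1 to compound 3 (within the scatter) and no change at the digits printed from compound 2 to compound 3 (within the scatter), where a butylcarbonyl or a cyclobutylcarbonyl was exchanged for the 2-(dimethylamino)ethyl chain with no movement beyond the scatter. So far, changing what sits on that nitrogen, whether a chain on a carbonyl carbon, a ring on a carbonyl carbon, or the 2-(dimethylamino)ethyl chain, has left the percentage of inhibition in this assay where it was. On this evidence the step of no change at the digits printed from compound 3 to compound 4 (within the scatter) is expected to stay within the scatter, with no direction favoured. Compound 4 is therefore estimated at 52% in this assay, with a range from 35% to 69%.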

Compound 4, a percentage reported as inhibition, at one concentration (the size of the read-out at that concentration, not a potency): 16%
Compound 4: middle estimate off by 36 percentage points, on the high side, and the stated range ends above it.
By their numbers in this assay, from the lowest: compound 4; then compounds 1, 2 and 3 (each within the scatter of the next).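

In this assay the group on this ring nitrogen turns out not to be a silent position: with phenyl in place of (dimethylamino)methyl on the saturated chain carbon, the result is a number 36 percentage points lower from compound 3 to compound 4 (beyond the scatter) and the flat picture ends. The same gap appears against the two compounds that carry a carbonyl on that nitrogen, with a number 36 percentage points lower from compound 2 to compound 4 (beyond the scatter) for benzyl in place of cyclobutylcarbonyl and a number 36 percentage points lower from compound 1 to compound 4 (beyond the scatter) for benzyl in place of butylcarbonyl, so three quite different groups sit level while benzyl alone stands apart. Nothing available here accounts for this drop.

The compounds shown cannot separate the effect of the phenyl ring entering from that of the dimethylamino end leaving, and a plain propyl chain on that nitrogen, or a 2-phenylethyl chain with the ring one carbon further out, would help to pull the two apart. Also open, going by these compounds, is whether a benzoyl group, which sets a phenyl ring on a carbonyl carbon, would stay level with compound 1 and compound 2 or fall towards compound 4.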